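The source may hold more compounds than are shown below. What is called first, only, known or untested is meant among the compounds shown, and "the series" means these compounds.

Compound 1, with the structure `CCCNC(=C\C(=O)/C=C/c1ccc(O)c(OC)c1)/C=C/c1ccc(O)c(OC)c1`, is the weaker of the two measured compounds. In a functional assay on EA.hy 926 cells (Homo sapiens), read by fluorescence, tested at 1 uM (a lower number here means a weaker effect, a higher number a stronger effect of the compound at the concentration tested), compound 1 gives 78%. The other measured compound, compound 2, whose structure is `CCC(C)NC(=C\C(=O)/C=C/c1ccc(O)cc1)/C=C/c1ccc(O)cc1`, gives in this assay a value of 99%, a higher reading that lies beyond the usual scatter of this kind of measurement, though the two structures differ in more than one place, so no single change can be tied to that gap.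

Compound 3, with the structure `CCCCNC(=C\C(=O)/C=C/c1ccc(O)c(OC)c1)/C=C/c1ccc(O)c(OC)c1`, has not yet been measured in this assay. It differs from compound 1 in one place: methyl in place of hydrogen on a saturated chain carbon, three bonds along the chain from an amine nitrogen. Propyl becomes butyl. On the numbers in hand, this small extension is expected to move the value of this assay by a number 4 percentage points higher from compound 1 to compound 3 (within the scatter), an upward shift within or near the scatter. Compound 3 is therefore estimated at 82% in this assay, with a range from 62% to 96%.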

Compound 3, a percentage reported as activity, at one concentration (the size of the read-out at that concentration, not a potency): 110%
Estimate against measurement, compound 3: 28 percentage points below; measured number above the stated range.
By their numbers in this assay, from the lowest: compound 1; then compound 2; then compound 3.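

The position three bonds along the chain from the amine nitrogen proves responsive in this assay: methyl in place of hydrogen on this saturated chain carbon, which turns propyl into butyl, gives a number 32 percentage points higher from compound 1 to compound 3 (beyond the scatter) on an otherwise unchanged core. Within the data shown here, this is the first change that can be tied to a single place, and it shows that one added methyl at the end of this chain can produce a large step. Nothing measured here accounts for the size of that step.

On these data alone, it remains open whether the reading keeps rising with a longer chain such as pentyl or hexyl, or whether butyl is already the turning point. Also open, as far as these compounds go, is how ethyl, a branched isobutyl or a terminal hydroxyl at this position would read on the same core.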